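Chloro on the Aromatic Ring, Ester and Amide Side by Side

This account rests on a few compounds, and the source may have more. Where it says the series, first, only, none or still open, it means among the compounds named here.

Compound 1, `CN1CC[C@H]2CCC[C@@H](OC(=O)c3ccccc3)[C@H]2C1`, gives 9.05.
Compound 2, `CN1CC[C@H]2CCC[C@@H](OC(=O)c3ccc(Cl)cc3)[C@H]2C1`, gives 8.9.
Compound 3, `CN1CC[C@H]2CCC[C@@H](NC(=O)c3ccccc3)[C@@H]2C1`, gives 8.99.

These three compounds were measured in a physicochemical assay for acid dissociation. Compound 1 and compound 2 differ in one place: chloro in place of hydrogen on an aromatic carbon. That change made the step of a number 0.15 log units lower from compound 1 to compound 2 (within the scatter). Compound 3 has a different core from compound 1; the difference between the two cores is not broken down here. What compound 3 and compound 1 show in this assay is a pair of numbers within the scatter of each other.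

Compound 4, `CN1CC[C@H]2CCC[C@@H](NC(=O)c3ccc(Cl)cc3)[C@@H]2C1`, is not yet measured. It differs from compound 3 in one place: chloro in place of hydrogen on an aromatic carbon. The place of the change is described in the same words for both pairs, so this is the same change made on the core of compound 3. The expected step, a number 0.14 log units lower from compound 3 to compound 4 (within the scatter), is estimated to match the earlier one because a number 0.15 log units lower from compound 1 to compound 2 (within the scatter) was small and within the scatter. Compound 4 is therefore expected to give 8.85 in this assay, with a likely range from 8.6 to 9.1.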

Compound 4, acid dissociation constant: 8.83
Estimate against measurement, compound 4: 0.02 log units above; the measured number falls inside the stated range.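

In this assay the change from phenyl to 4-chlorophenyl gave a number 0.16 log units lower from compound 3 to compound 4 (within the scatter) and, on the other core, a number 0.15 log units lower from compound 1 to compound 2 (within the scatter) so on both cores the step stays inside the normal spread of repeat measurements. This shows that the change behaved alike on these two cores, in the limited sense that neither step can be told apart from no change at all, but it does not show that chloro truly lowers the number, and two pairs make no rule for other cores in the series. Nothing measured here offers a reason for the size of either step.

The compounds shown leave open whether a different group on the aromatic ring, such as an amine, a carboxylic acid or a methoxy group, would give a step that clears the scatter. They also leave open whether chloro would behave the same way on a core other than these two.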